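Side-chain exchange from compound 2 to compound 3

The source may hold more compounds than are shown below. What is called first, only, known or untested is meant among the compounds shown, and "the series" means these compounds.

In a functional assay on A549 cells (Homo sapiens) for cytotoxicity, read by sulforhodamine B assay (on this read-out higher numbers stand for weaker inhibition and lower numbers for stronger inhibition), compound 1 `COCCNc1nc(-c2ccccc2)nc2ccccc12` gives 27.5 ug/mL on this scale and compound 2 `CN1CCCN(c2nc(-c3ccccc3)nc3ccccc23)CC1` gives 24.1 ug/mL on the same scale, so the two stand within the scatter of each other. Next comes compound 3 `COC(=O)CNc1nc(-c2ccccc2)nc2ccccc12`, with the change ((methoxycarbonyl)methyl)amino in place of 4-methyl-1,4-diazepan-1-yl on an aromatic carbon at the same aromatic carbon of the shared core. Among the compounds with values here, only one measured step bears on it: a 1.1-fold lower number from compound 1 to compound 2 (0.06 log units; within the scatter) in a swap that also involved 4-methyl-1,4-diazepan-1-yl, and it stayed within the scatter. Within the data shown here, the entering ((methoxycarbonyl)methyl)amino is, like the (2-methoxyethyl)amino of compound 1, a chain with no ring, but no compound with this group has been measured. In this assay the expected result is a 1.0-fold higher number from compound 2 to compound 3 (0.02 log units; within the scatter) and no step beyond the scatter, with either direction open. Compound 3 is estimated at 25 ug/mL within an expected range of 10 ug/mL to 60 ug/mL for this side chain.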

Compound 3, half-maximal inhibitory concentration: 36.3 ug/mL
The estimate for compound 3 lay 1.5-fold (0.16 log units) below the measured number, within the range that was stated.
By their numbers in this assay, from the lowest: compounds 2, 1 and 3 (each within the scatter of the next).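

In this assay, the exchange of 4-methyl-1,4-diazepan-1-yl for ((methoxycarbonyl)methyl)amino on this aromatic carbon gives (a 1.5-fold higher number from compound 2 to compound 3 (0.18 log units; within the scatter)), so removing the seven-membered ring and adding a hydrogen-bond donor and a double bond outside the aromatic rings leaves the number within the scatter. Between the two ring-free chains, methoxycarbonyl in place of methoxymethyl gives (a 1.3-fold higher number from compound 1 to compound 3 (0.12 log units; within the scatter)), so this change on the chain also produces no step beyond the scatter, and all three side chains at this position now stand within the scatter of the next. No measurement at hand bears on why these steps are small.

Going by these compounds, whether a carboxylic acid in place of the methyl ester, a primary amine or a longer chain at this position would give a step beyond the scatter stays open. Also open, on these data alone, is whether replacing the phenyl group, common to all three compounds, would matter more than the side chain.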